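Replacing tert-butyl with methoxy in compound 3

This account rests on a few compounds, and the source may have more. Where it says the series, first, only, none or still open, it means among the compounds named here.

Compound 1 `O=C(CCc1cccc2c1B(O)OC2)Nc1ccc(Cl)cc1` gives 5000 nM in a functional assay on SK-OV-3 cells (Homo sapiens) for antiproliferative activity, read by MTT assay, with a stated time of 72 h; on this read-out lower numbers stand for stronger inhibition and higher numbers for weaker inhibition
Compound 2 `O=C(CCc1cccc2c1B(O)OC2)Nc1ccc(Br)cc1` gives 9200 nM
Compound 3 `CC(C)(C)c1ccc(NC(=O)CCc2cccc3c2B(O)OC3)cc1` gives 4200 nM

Two steps fix the standing of compound 3: a 1.2-fold lower number from compound 1 to compound 3 (0.08 log units; within the scatter) and a 2.2-fold lower number from compound 2 to compound 3 (0.34 log units; beyond the scatter). It is therefore level with compound 1 and only modestly apart from compound 2. Compound 4 `COc1ccc(NC(=O)CCc2cccc3c2B(O)OC3)cc1` carries methoxy in place of tert-butyl on an aromatic carbon, para to a large group: methoxy in place of tert-butyl on an aromatic carbon. Among the compounds with values here, no measured compound has methoxy, so the evidence is indirect. The swaps at this place gave small steps, including a 1.8-fold higher number from compound 1 to compound 2 (0.26 log units; within the scatter), so no step beyond the scatter is expected in this assay. The expected change is a 1.4-fold higher number from compound 3 to compound 4 (0.15 log units; within the scatter), a slight lean towards a higher number. Compound 4 is estimated at 6000 nM, with an expected range from 3000 nM to 12000 nM.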

Compound 4, half-maximal inhibitory concentration: 900 nM
The estimate for compound 4 lay 6.7-fold (0.82 log units) above the measured number, and the stated range ends above it.
By their numbers in this assay, from the lowest: compound 4; then compounds 3, 1 and 2 (each within the scatter of the next, the first and the last beyond it).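

In this assay, methoxy on this aromatic carbon, para to a large group, sets compound 4 apart from all three earlier compounds: a 4.7-fold lower number from compound 3 to compound 4 (0.67 log units; beyond the scatter), a 5.6-fold lower number from compound 1 to compound 4 (0.74 log units; beyond the scatter) and a 10-fold lower number from compound 2 to compound 4 (1.01 log units; beyond the scatter). Chloro, bromo and tert-butyl had differed by modest steps at most, so this position allows a much wider spread of numbers than they showed. Nothing in the data shown accounts for the difference.

As far as these compounds go, whether ethoxy or hydroxy would keep the low number of compound 4 remains open. So does whether an amine at this place would do the same.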